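From diethylamino to dimethylamino on a shared core

This account rests on a few compounds, and the source may have more. Where it says the series, first, only, none or still open, it means among the compounds named here.

Compound 1 `CCN(CC)c1ccc(-c2ccc(C#N)cc2)nn1` gives > 25000 nM
Compound 2 `CCN(CC)c1ccc(-c2ccc(C(=O)OC)cc2)nn1` gives 140 nM

Both compounds were tested in a functional assay on MDA-MB-231 cells (Homo sapiens) for antiproliferative activity, with a stated time of 48 h; on this read-out lower numbers stand for stronger inhibition and higher numbers for weaker inhibition. For compound 1 the entry > 25000 nM is a limit of the assay and not a number. Among the measured compounds shown here, compound 2, at 140 nM, therefore holds the only true number so far, and nothing measured yet stands on either side of it.

Compound 3 `COC(=O)c1ccc(-c2ccc(N(C)C)nn2)cc1` keeps the methoxycarbonyl group of compound 2 and alters one substituent: dimethylamino in place of diethylamino on an aromatic carbon. This puts dimethylamino in place of diethylamino on an aromatic carbon, para to a large group.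

For the measured compounds named here, only one measured step exists, an at least 170-fold lower number from compound 1 to compound 2 (2.25 log units; beyond the scatter). That step is large, but it exchanged cyano for methoxycarbonyl and left the diethylamino group untouched. It shows that this assay can respond strongly within this small set, yet no measurement tests the present change. A small move towards a higher number is expected, and a result within the scatter would be no surprise. The expected change is a 2.1-fold higher number from compound 2 to compound 3 (0.33 log units; beyond the scatter). For compound 3 the estimated value is 300 nM, with an expected range from 80 nM to 1500 nM.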

Compound 3, half-maximal inhibitory concentration: > 25000 nM
Compound 3 ended at the assay's limit (the forecaster's own chance of this, stated with the estimate: 5%); middle value at least 83-fold (1.92 log units) from the limit.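

In this assay, dimethylamino in place of diethylamino on an aromatic carbon gave an at least 170-fold higher number from compound 2 to compound 3 (2.25 log units; beyond the scatter), so the amino substituent, left untouched by the earlier step, an at least 170-fold lower number from compound 1 to compound 2 (2.25 log units; beyond the scatter), is also a place where this read-out responds strongly. Going by these compounds, for compound 3 the entry > 25000 nM is a limit of the assay and not a number, so the true size of the step stays unknown. Among the compounds shown, only compound 2, which joins methoxycarbonyl with diethylamino, gives a true number, and replacing either group in turn ends at the same limit: the limit of > 25000 nM in this assay, at which 2 of the 3 values shown sit.

The compounds shown leave open how the number moves with a longer chain on the amine nitrogen, such as dipropylamino, or with a ring amine such as pyrrolidine in the same place. Also open, on these data alone, is whether the methoxycarbonyl group can give way to a carboxylic acid or an amide while diethylamino stays, and whether a true number would survive that exchange.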